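Replacing a Chlorinated Phenyl Ring with Pyridin-2-yl

The source may hold more compounds than are shown below. What is called first, only, known or untested is meant among the compounds shown, and "the series" means these compounds.

Compound 1 `S=c1oc(-c2ccc3c(c2)OCCO3)nn1CN1CCN(c2cccc(Cl)c2)CC1` was tested in a functional assay on HepG2 cells (Homo sapiens) for antiproliferative activity, read by MTT assay, with a stated time of 48 h; on this read-out higher numbers stand for weaker inhibition and lower numbers for stronger inhibition. In this assay compound 1 gives > 50000 nM, which is a limit of the assay rather than a number. Compound 2 `Fc1ccc(N2CCN(Cn3nc(-c4ccc5c(c4)OCCO5)oc3=S)CC2)cc1` likewise gives > 50000 nM, again a limit. Compound 3 `COc1cccc(N2CCN(Cn3nc(-c4ccc5c(c4)OCCO5)oc3=S)CC2)c1` gives 21400 nM. Within the data shown here, from compound 1 only one readable step exists, an at least 2.3-fold lower number from compound 1 to compound 3 (0.36 log units; beyond the scatter), while a step that the two limits leave unreadable from compound 1 to compound 2. Compound 4 `S=c1oc(-c2ccc3c(c2)OCCO3)nn1CN1CCN(c2ccccn2)CC1` differs from compound 1 by pyridin-2-yl in place of 3-chlorophenyl on an amine nitrogen in a ring. Among the measured compounds shown here, no measured step brings in a ring carrying a nitrogen, so the measured moves give only a rough guide. Compound 1 and compound 2 both sit at the limit of > 50000 nM in this assay, at which 2 of the 3 values shown sit, so compound 4 is expected to stay near that limit, a number no higher from compound 1 to compound 4 (the limit leaves the size open). The estimate for compound 4 is 50000 nM, within 20000 nM to 100000 nM.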

Compound 4, half-maximal inhibitory concentration: 11400 nM
Compound 4: middle estimate off by 4.4-fold (0.64 log units), on the high side; the whole stated range lies above it.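

In this assay, pyridin-2-yl on this amine nitrogen outdoes both halogen-bearing phenyl rings, with an at least 4.3-fold lower number from compound 1 to compound 4 (0.64 log units; beyond the scatter) and an at least 4.3-fold lower number from compound 2 to compound 4 (0.64 log units; beyond the scatter). Compound 1 and compound 2 each stand at a limit rather than a number: the limit of > 50000 nM in this assay, at which 2 of the 4 values shown sit. Against 3-methoxyphenyl the change gives a 1.9-fold lower number from compound 3 to compound 4 (0.27 log units; within the scatter), so a ring carrying a nitrogen is tolerated at this position but cannot be told apart from that group.

Going by these compounds, whether the place of the ring nitrogen matters stays open. Pyridin-3-yl, pyridin-4-yl and unsubstituted phenyl on the same amine nitrogen would help to settle that.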